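Allylsulfanyl in Place of Benzamido on the Shared Core

The compounds below may be only part of what the source reports. "The series", "measured", "known", "first", "only" and "open" are said of these compounds alone.

- Compound 1 `Cc1ccc(-c2nc(N)c3cc(Cl)ccc3n2)cc1`: 14.5 ug/mL
- Compound 2 `Cc1ccc(-c2nc(NC(=O)c3ccccc3)c3cc(Cl)ccc3n2)cc1`: 17.5 ug/mL
- Compound 3 `Cc1ccc(-c2nc(NOC(=O)c3ccccc3)c3cc(Cl)ccc3n2)cc1`: 12.1 ug/mL

In a functional assay on HepG2 cells (Homo sapiens) for antiproliferative activity, read by MTT assay, with a stated time of 48 h (on this read-out lower numbers stand for stronger inhibition and higher numbers for weaker inhibition), compound 2 cannot be told apart from the other two measured compounds: a 1.2-fold higher number from compound 1 to compound 2 (0.08 log units; within the scatter), and a 1.4-fold lower number from compound 2 to compound 3 (0.16 log units; within the scatter). Compound 4 `C=CCSc1nc(-c2ccc(C)cc2)nc2ccc(Cl)cc12` carries allylsulfanyl in place of benzamido on an aromatic carbon. A third step, a 1.2-fold lower number from compound 1 to compound 3 (0.08 log units; within the scatter), also bears on this change. Among the measured compounds shown here, all three steps altered the group on the same nitrogen and stayed small, but none removes that nitrogen, so the data offer no direct precedent. No step beyond the scatter is therefore expected in this assay, and no direction is favoured. The expected change is a 1.2-fold lower number from compound 2 to compound 4 (0.07 log units; within the scatter). For compound 4 the estimated value is 15 ug/mL, with an expected range of 6 ug/mL to 35 ug/mL.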

Compound 4, half-maximal inhibitory concentration: 23.9 ug/mL
The estimate for compound 4 lay 1.6-fold (0.20 log units) below the measured number, and the stated range covers the measured number.
By their numbers in this assay, from the lowest: compounds 3, 1, 2 and 4 (each within the scatter of the next).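

Compound 4 is the first compound shown without a nitrogen on this aromatic carbon, yet in this assay neither step leaves the scatter: a 1.4-fold higher number from compound 2 to compound 4 (0.14 log units; within the scatter) and a 1.6-fold higher number from compound 1 to compound 4 (0.22 log units; within the scatter). At this position, then, allylsulfanyl, attached through sulfur and carrying no ring, can stand in place of benzamido or amino without a step beyond the scatter.

From the compounds shown here alone, whether a carboxylic acid, a dimethylamino group or a longer chain such as hexylsulfanyl on this carbon would move the number beyond the scatter remains open. No measurement shown explains these numbers.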